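Capping a Piperazine Nitrogen in Sub-Nanomolar Serotonin Receptor Ligands

This account rests on a few compounds, and the source may have more. Where it says the series, first, only, none or still open, it means among the compounds named here.

Three compounds have been measured in an assay on isolated protein for inhibition of 5-hydroxytryptamine receptor 4 (Homo sapiens); on this read-out lower numbers stand for stronger inhibition and higher numbers for weaker inhibition:

Compound 1, `CCN1CCN(S(=O)(=O)CCCN2CCC(CNC(=O)c3cccc4c3OCCO4)CC2)CC1`: 0.0501 nM
Compound 2, `CC1(C)CCN(S(=O)(=O)CCCN2CCC(CNC(=O)c3cccc4c3OCCO4)CC2)CC1`: 0.126 nM
Compound 3, `O=C(NCC1CCN(CCCS(=O)(=O)N2CCNCC2)CC1)c1cccc2c1OCCO2`: 0.159 nM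

Compound 3 stands clearly apart from compound 1 only, as a 3.2-fold higher number from compound 1 to compound 3 (0.50 log units; beyond the scatter) shows; its gap to compound 2 lies within the scatter. Compound 4, `CC(C)S(=O)(=O)N1CCN(S(=O)(=O)CCCN2CCC(CNC(=O)c3cccc4c3OCCO4)CC2)CC1`, differs from compound 3 in one place: isopropylsulfonyl in place of hydrogen on an amine nitrogen in a ring. The step on the same ring nitrogen, a 3.2-fold higher number from compound 1 to compound 3 (0.50 log units; beyond the scatter), is the most relevant and was modest. Changes at the sulfonyl end, a 2.5-fold higher number from compound 1 to compound 2 (0.40 log units; beyond the scatter) and a 1.3-fold higher number from compound 2 to compound 3 (0.10 log units; within the scatter), were modest or within the scatter. A group entering on that nitrogen is therefore expected to move the number only a little. Compound 4 is estimated at 0.2 nM, between 0.05 nM and 0.8 nM. This means an expected step of a 1.3-fold higher number from compound 3 to compound 4 (0.10 log units; within the scatter).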

Compound 4, inhibition constant: 0.126 nM
The estimate for compound 4 lay 1.6-fold (0.20 log units) above the measured number; the range from low to high includes it.
By their numbers in this assay, from the lowest: compound 1; then compounds 2, 4 and 3 (each within the scatter of the next).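

On the ring nitrogen of compound 3, hydrogen can give way to isopropylsulfonyl, a much larger group with no net charge, and the number stays within the scatter (a 1.3-fold lower number from compound 3 to compound 4 (0.10 log units; within the scatter)) in this assay. The same holds for the exchange of 4,4-dimethylpiperidin-1-yl for 4-(isopropylsulfonyl)piperazin-1-yl (no change at the digits printed from compound 2 to compound 4 (within the scatter)), whereas ethyl on that nitrogen keeps the lower number (a 2.5-fold higher number from compound 1 to compound 4 (0.40 log units; beyond the scatter)). No measurement at hand explains these results. On these data alone, whether a benzoyl group, a carboxylic acid or a longer chain ending in an amine would be accepted on that nitrogen remains open.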